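A few compounds are considered here, and "the series" means these few. Any claim that something is new, unique, unknown or untested is made for them only; others in the source may bear on it.

In a functional assay on PC-3 cells (Homo sapiens) for inhibition, read by colorimetric assay and MTT assay, with a stated time of 72 h (on this read-out higher numbers stand for weaker inhibition and lower numbers for stronger inhibition), three compounds sharing one core and differing only in a single chain have been measured. Compound 1 (`C=CCCCCOc1ccccc1-c1cnc(OCCC=C)n1C`) gives 19000 nM, compound 2 (`C=CCCCCOc1ccccc1-c1cnc(OCCCCC=C)n1C`) gives 9000 nM, and compound 3 (`C=CCCCCOc1ccccc1-c1cnc(OCCOCC=C)n1C`) gives 36000 nM. Compound 3 cannot be told apart from compound 1, with a 1.9-fold higher number from compound 1 to compound 3 (0.28 log units; within the scatter) lying within the scatter, but it separates from compound 2, with a 4.0-fold higher number from compound 2 to compound 3 (0.60 log units; beyond the scatter) lying beyond it.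

Compound 4 (`C=CCCCCOc1ccccc1-c1cnc(S(=O)(=O)c2ccccc2)n1C`) keeps the core and exchanges that chain: phenylsulfonyl in place of 2-(allyloxy)ethoxy on an aromatic carbon. Phenylsulfonyl replaces 2-(allyloxy)ethoxy on an aromatic carbon, between two ring nitrogen atoms.

The measured steps at this place are all swaps from one chain to another. Alongside the two steps above stands a 2.1-fold lower number from compound 1 to compound 2 (0.32 log units; beyond the scatter), also modest. None of them introduces a sulfonyl group or a ring, so they offer only a rough guide to size. The largest is a 4.0-fold higher number from compound 2 to compound 3 (0.60 log units; beyond the scatter), and a step of about that modest size is expected in this assay. A lower number is the likelier direction, though only weakly, as compound 2 at 9000 nM shows that lower numbers are reachable at this place. The estimated change is a 3.0-fold lower number from compound 3 to compound 4 (0.48 log units; beyond the scatter). Compound 4 is estimated at 12000 nM, with an expected range from 3000 nM to 45000 nM.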

Compound 4, half-maximal inhibitory concentration: 33000 nM
Beside the measured number, compound 4's estimate is 2.8-fold (0.44 log units) below it, within the range that was stated.
By their numbers in this assay, from the lowest: compound 2; then compounds 1, 4 and 3 (each within the scatter of the next).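

In this assay, the aromatic carbon between two ring nitrogen atoms now proves to take a group of a different kind, since phenylsulfonyl brings a six-membered aromatic ring of carbon only, and yet a 1.1-fold lower number from compound 3 to compound 4 (0.04 log units; within the scatter) and a 1.7-fold higher number from compound 1 to compound 4 (0.24 log units; within the scatter) both lie within the scatter. Within the data shown here, compound 2 alone stands apart, with a 3.7-fold higher number from compound 2 to compound 4 (0.56 log units; beyond the scatter) beyond the scatter, so its (hex-5-en-1-yl)oxy chain remains the only group here that separates from all the others, now including one that is not a chain. No evidence accompanies these numbers to account for any of these steps.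

The compounds shown leave open whether the sulfonyl link or the aromatic ring carries the result, as a plain phenyl group or a methylsulfonyl group at this carbon would separate the two. They also leave open whether a longer chain than (hex-5-en-1-yl)oxy, or an amine or a carboxylic acid at the same place, would move the number beyond the range seen so far.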